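A few compounds are considered here, and "the series" means these few. Any claim that something is new, unique, unknown or untested is made for them only; others in the source may bear on it.

Three compounds were measured in a functional assay on the whole organism for inhibition, with Rattus norvegicus as the target, at a dose of 30 mg/kg; a higher number here means more inhibition at the dose given (going by the name of the read-out), a lower number less inhibition:

compound 1, `Clc1ccccc1-c1nc2ncccc2o1`, gives 38%
compound 2, `Cc1ccccc1-c1nc2ncccc2o1`, gives 0%
compound 3, `Cc1cccc(-c2nc3cccnc3o2)c1`, gives 14%

Compound 2 and compound 3 are built from the same atoms joined differently; the difference between the two cores is not broken down here. Compound 1 differs from compound 2 by chloro in place of methyl on an aromatic carbon, and this step gives a number 38 percentage points higher from compound 2 to compound 1 (beyond the scatter). Compound 4, `Clc1cccc(-c2nc3cccnc3o2)c1`, differs from compound 3 by chloro in place of methyl on an aromatic carbon. This is the same kind of change, not the same: in compound 1 the chloro sits ortho to a group of 9 heavy atoms, in compound 4 meta to it. Compound 4 is expected to rise by a number 21 percentage points higher from compound 3 to compound 4 (beyond the scatter), a smaller step than the earlier one, because a number 38 percentage points higher from compound 2 to compound 1 (beyond the scatter) comes from a different place on the ring. The estimate for compound 4 is 35%, between 15% and 60%.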

Compound 4, a percentage reported as inhibition, in the whole organism at one dose (the size of the read-out at that dose, not a potency): 8%
Compound 4: middle estimate off by 27 percentage points, on the high side; the whole stated range lies above it.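

In this assay, chloro in place of methyl gives a number 6 percentage points lower from compound 3 to compound 4 (within the scatter), so on this core the change leaves no readable effect. The earlier step therefore does not carry over from one core to the other: the same change on two cores in this assay, a number 38 percentage points higher (beyond the scatter) from compound 2 to compound 1 and a number 6 percentage points lower (within the scatter) from compound 3 to compound 4, 44 percentage points apart, beyond the scatter of two such steps

This does not show whether the core or the place of the chloro accounts for the gap: in compound 4 the chloro is meta to a group of 9 heavy atoms, in compound 1 it stands at another place on the ring, and the two pairs differ in both respects.

The compounds shown carry only chloro or methyl on this ring. On these data alone, how an amine or a carboxylic acid would read at either place in this assay remains open.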